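From chloro to trifluoromethyl on a shared core

The source may report more compounds than this note shows. Statements on the series, on what has been measured and on what is new or still open speak of the compounds shown alone.

Of the compounds shown here, three built on one shared core have been measured in an ADME assay on cells (Hepatocyte, Mus musculus) for cytotoxicity, read by MTT assay, with a stated time of 24 h; a higher number here means that more compound is tolerated, a lower number that less compound is tolerated. Compound 1 `Cc1ccc(-c2nn(-c3ccccc3)cc2-c2nc3ccccc3n2S(=O)(=O)c2ccc(C(F)(F)F)cc2)cc1` gives 89300 nM, compound 2 `O=[N+]([O-])c1ccc(S(=O)(=O)n2c(-c3cn(-c4ccccc4)nc3-c3ccc(C(F)(F)F)cc3)nc3ccccc32)cc1` gives 178000 nM, and compound 3 `O=S(=O)(c1ccc(Cl)cc1)n1c(-c2cn(-c3ccccc3)nc2-c2ccc(C(F)(F)F)cc2)nc2ccccc21` gives 173000 nM. Compound 3 lies within the usual scatter of both other compounds, so the numbers set no real order around it.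

The next compound, compound 4 `O=S(=O)(c1ccc(C(F)(F)F)cc1)n1c(-c2cn(-c3ccccc3)nc2-c2ccc(C(F)(F)F)cc2)nc2ccccc21`, keeps the structure of compound 3 except for one group: trifluoromethyl in place of chloro on an aromatic carbon. Put simply, trifluoromethyl takes the place of chloro on an aromatic carbon, para to a large group. One measured step involves a change to this chloro group: chloro in place of nitro on an aromatic carbon gave a 1.0-fold lower number from compound 2 to compound 3 (0.01 log units; within the scatter). That change left the number within the scatter. Going by the values given here, no measured step replaces chloro with trifluoromethyl directly, so this is thin evidence, and it points to no clear direction. The expected change in this assay is therefore small and within the scatter, estimated as a 1.2-fold lower number from compound 3 to compound 4 (0.06 log units; within the scatter). For compound 4 the estimated value is 150000 nM, with an expected range from 80000 nM to 280000 nM.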

Compound 4, half-maximal cytotoxic concentration: 137000 nM
For compound 4 the middle estimate is 1.1-fold (0.04 log units) above the measured one, within the range that was stated.
By their numbers in this assay, from the lowest: compounds 1, 4, 3 and 2 (each within the scatter of the next).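

In this assay, trifluoromethyl in place of chloro gave a 1.3-fold lower number from compound 3 to compound 4 (0.10 log units; within the scatter) and trifluoromethyl in place of nitro gave a 1.3-fold lower number from compound 2 to compound 4 (0.11 log units; within the scatter) at the same aromatic carbon, para to a large group. With a third group now read there, nitro, chloro and trifluoromethyl all lie within the scatter of one another, so this place shows no readable preference among these three groups in how much compound the cells tolerate. Compound 4 also links to compound 1, where trifluoromethyl in place of methyl gave a 1.5-fold higher number from compound 1 to compound 4 (0.19 log units; within the scatter) at another aromatic carbon of the molecule, and this step also stays within the scatter. No other measurement shown here bears on these numbers.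

Going by these compounds, what remains open is whether any group at this aromatic carbon can move the number beyond the scatter, for example an amine, a carboxylic acid or a longer chain such as butyl. The compounds shown also leave open whether a hydroxyl or a methoxy group on the same carbon would behave like the three groups read so far.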